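A Fluoro-for-Methoxy Swap Tested Against a Cytotoxicity Limit

The compounds below may be only part of what the source reports. "The series", "measured", "known", "first", "only" and "open" are said of these compounds alone.

Compound 1 `C=CC1=C(C(=O)NC(C)(C)C)C(c2ccc(OC)cc2)OC1`: > 100000 nM (a limit).
Compound 2 `C=CC1=C(C(=O)Nc2ccc(OCC)cc2)C(c2ccc(OC)cc2)OC1`: > 100000 nM (a limit).

In a functional assay on HeLa cells (Homo sapiens) for cytotoxicity, read by MTT assay, with a stated time of 24 h (on this read-out lower numbers stand for stronger inhibition and higher numbers for weaker inhibition), compound 1 reaches only the assay limit of > 100000 nM. In this assay compound 2 likewise stands at the limit of > 100000 nM, not at a number. Among the compounds with values here, the one measured step, a step that the two limits leave unreadable from compound 1 to compound 2, cannot be sized because of the limit of > 100000 nM in this assay, at which 2 of the 2 values shown sit. Compound 2 thus stands at the top of the measured range, with no number to place it more closely.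

Compound 3 `C=CC1=C(C(=O)Nc2ccc(OCC)cc2)C(c2ccc(F)cc2)OC1` carries a single change: fluoro in place of methoxy on an aromatic carbon. Within the data shown here, no measured step touches this part of the molecule, and the only step known, a step that the two limits leave unreadable from compound 1 to compound 2, is itself unreadable; there is no measured basis for a step beyond the scatter in this assay in either direction. Compound 3 is therefore expected to remain at the limit, with an estimate of 150000 nM in a range of 50000 nM to 600000 nM. That estimate implies a step that the limit leaves unreadable from compound 2 to compound 3, expected rather than measured.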

Compound 3, half-maximal inhibitory concentration: > 100000 nM
Compound 3 gave a limit, no number (the forecaster's own chance of this, stated with the estimate: 85%); the middle value does not contradict the limit.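

Within the data shown here, compound 3 sits at a limit in this assay, as compound 2 does, so fluoro in place of methoxy yields no step that can be read between them: the limit of > 100000 nM in this assay, at which 3 of the 3 values shown sit.

The compounds shown leave open how far beyond the limit each lies, and whether fluoro and methoxy would differ on a numbered value.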